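Replacing methoxy with 1-hydroxyethyl in an antiproliferative pair

The source may report more compounds than this note shows. Statements on the series, on what has been measured and on what is new or still open speak of the compounds shown alone.

Compound 1 (`CC(Nc1ccccc1Oc1ccc(Cl)cc1)=C1C(=O)CC(c2ccccc2)CC1=O`) and compound 2 (`COc1ccc(Oc2ccccc2NC(C)=C2C(=O)CC(c3ccccc3)CC2=O)cc1`) share one core and differ in a single group. In a functional assay on L1210 cells (Mus musculus) for antiproliferative activity, read by cell counting, with a stated time of 96 h (on this read-out higher numbers stand for weaker inhibition and lower numbers for stronger inhibition), compound 1 gives 250 nM as its result, and compound 2 gives 140 nM as its result. Within the data shown here, compound 2 therefore stands within the usual scatter of compound 1, the only other measured compound, and the two cannot be ranked.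

Compound 3 (`CC(Nc1ccccc1Oc1ccc(C(C)O)cc1)=C1C(=O)CC(c2ccccc2)CC1=O`) carries 1-hydroxyethyl in place of methoxy on an aromatic carbon, para to a large group (1-hydroxyethyl in place of methoxy on an aromatic carbon). Among the measured compounds shown here, the only measured guide is a 1.8-fold lower number from compound 1 to compound 2 (0.25 log units; within the scatter) for methoxy in place of chloro on an aromatic carbon. For the measured compounds named here, that step involved different groups, and no measured compound carries 1-hydroxyethyl, so the evidence is thin. No step beyond the scatter is therefore expected in this assay and neither direction is clearly favoured. The estimated change is a 1.4-fold higher number from compound 2 to compound 3 (0.15 log units; within the scatter) as a working figure. For compound 3 the estimated value is 200 nM with an expected range from 70 nM to 600 nM in this measurement.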

Compound 3, half-maximal inhibitory concentration: 58 nM
For compound 3 the middle estimate is 3.4-fold (0.54 log units) above the measured one; measured number outside the range, below it.
By their numbers in this assay, from the lowest: compound 3; then compounds 2 and 1 (each within the scatter of the next).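

In this assay, among these compounds, a 2.4-fold lower number from compound 2 to compound 3 (0.38 log units; beyond the scatter) and a 4.3-fold lower number from compound 1 to compound 3 (0.63 log units; beyond the scatter) are the first steps beyond the scatter at this position, where the swap from chloro to methoxy had not separated the compounds. The group on this aromatic carbon, para to a large group, can therefore shift the number, and with 1-hydroxyethyl the shift is toward stronger inhibition, although both steps are modest in size. The change also brings in a hydrogen-bond donor that methoxy lacks, but no supporting data here link that difference, or any other, to the result.

The compounds shown leave open whether the gain comes from the hydroxy group of 1-hydroxyethyl or from its carbon framework, a question that close relatives such as hydroxymethyl, ethyl or acetyl at the same place could help to separate. They also leave open whether an amine or a carboxylic acid at this position would lower the number further or raise it again, and whether the same change would hold on another core.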